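Aryl substituent on the pyridazinone nitrogen: compound 4

The source may hold more compounds than are shown below. What is called first, only, known or untested is meant among the compounds shown, and "the series" means these compounds.

Measured so far:
compound 1 `COc1cc2c(Oc3ccc(NC(=O)c4nn(-c5ccccc5)c(=O)cc4C)cc3F)ccnc2cc1OCCCN1CCCC1` 120 nM
compound 2 `COc1cc2c(Oc3ccc(NC(=O)c4nn(-c5ccccc5OC(F)(F)F)c(=O)cc4C)cc3F)ccnc2cc1OCCCN1CCCC1` 60 nM
compound 3 `COc1cc2c(Oc3ccc(NC(=O)c4nn(-c5ccccc5OC(F)(F)F)c(=O)cc4C)cc3F)ccnc2cc1OCCCN1CCCCC1` 40 nM

Compound 2 sits second highest of the three numbers in a functional assay on MKN-45 cells (Homo sapiens) for inhibition, read by MTT assay, with a stated time of 72 h; on this read-out lower numbers stand for stronger inhibition and higher numbers for weaker inhibition: compound 3 lies a 1.5-fold lower number from compound 2 to compound 3 (0.18 log units; within the scatter) and compound 1 a 2.0-fold lower number from compound 1 to compound 2 (0.30 log units; within the scatter), both within the scatter. Compound 4 `COc1ccc(-n2nc(C(=O)Nc3ccc(Oc4ccnc5cc(OCCCN6CCCC6)c(OC)cc45)c(F)c3)c(C)cc2=O)cc1` differs from compound 2 by 4-methoxyphenyl in place of 2-(trifluoromethoxy)phenyl on an aromatic nitrogen. Within the data shown here, only the step from compound 1 to compound 2 touches this aryl group, and it was a 2.0-fold lower number from compound 1 to compound 2 (0.30 log units; within the scatter), so substitution on that ring has so far moved this assay little. The step from compound 2 to compound 3 changes a different part and does not bear on it. Compound 4 is therefore expected to land near compound 2, a step of a 1.5-fold higher number from compound 2 to compound 4 (0.18 log units; within the scatter) at most, with no change beyond the scatter anticipated. The estimate for compound 4 in this assay is 90 nM, between 40 nM and 200 nM.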

Compound 4, half-maximal inhibitory concentration: 1290 nM
Beside the measured number, compound 4's estimate is 14-fold (1.16 log units) below it, and the stated range ends below it.
By their numbers in this assay, from the lowest: compounds 3, 2 and 1 (each within the scatter of the next, the first and the last beyond it); then compound 4.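

In this assay, the aryl group on the aromatic nitrogen proves far from neutral: 4-methoxyphenyl in place of 2-(trifluoromethoxy)phenyl weakens inhibition sharply (a 22-fold higher number from compound 2 to compound 4 (1.33 log units; beyond the scatter)). The same holds against the unsubstituted phenyl (an 11-fold higher number from compound 1 to compound 4 (1.03 log units; beyond the scatter)), so a substituent on this ring can move the number well beyond the scatter, which the earlier step on this ring did not show. No measurement here explains the loss.

Open, going by these compounds, is whether 2-methoxyphenyl or 4-(trifluoromethoxy)phenyl on the same nitrogen would stay near compound 2 or follow compound 4, which would separate the effect of the group from that of its place on the ring.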